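Working notes on two measured compounds and a third

A few compounds are considered here, and "the series" means these few. Any claim that something is new, unique, unknown or untested is made for them only; others in the source may bear on it.

Measured so far:
compound 1, `CCOC(=O)CCCC/C=C(\c1ccccc1)c1cccnc1`, 600 nM
compound 2, `O=C(O)CCCC/C=C(\c1cccnc1)c1ccsc1`, 31 nM

Both numbers come from an assay (Equus caballus) for inhibition of Thromboxane-A synthase (Homo sapiens), using microsomes; on this read-out lower numbers stand for stronger inhibition and higher numbers for weaker inhibition. Compound 2 gives 31 nM, the lower of the two numbers. Compound 1 gives 600 nM, a higher number, and the gap between the two lies beyond the scatter. Among the compounds with values here, compound 1 and compound 2 differ in more than one place, so the two values show only that compound 2 sits lower; which part of the structure carries the gap cannot be read from them.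

Compound 3, `Cc1ccc(/C(=C/CCCCC(=O)O)c2cccnc2)cc1`, has not yet been measured in this assay. It differs from compound 2 in one place: 4-methylphenyl in place of thiophen-3-yl on a double-bonded chain carbon bound to an aromatic carbon and a double-bonded chain carbon. The acid chain and the remainder of the molecule are kept.

Within the data shown here, no step between measured compounds covers this change, and the pair on hand says nothing about the group on the double-bonded chain carbon on its own. The expected step from compound 2 to compound 3 is a 1.9-fold higher number from compound 2 to compound 3 (0.29 log units; within the scatter), a small loss that may not exceed the scatter. Compound 3 is expected to give about 60 nM in this assay, with a range from 15 nM to 250 nM.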

Compound 3, half-maximal inhibitory concentration: 85 nM
For compound 3 the middle estimate is 1.4-fold (0.15 log units) below the measured one; the measured number falls inside the stated range.
By their numbers in this assay, from the lowest: compound 2; then compound 3; then compound 1.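

With the acid chain and the remainder of the molecule kept, the group on a double-bonded chain carbon bound to an aromatic carbon and a double-bonded chain carbon can now be read on its own in this assay. Here, 4-methylphenyl in place of thiophen-3-yl gives a 2.7-fold higher number from compound 2 to compound 3 (0.44 log units; beyond the scatter) as a modest step, so this position responds to the exchange of a five-membered aromatic ring with one hetero atom for a six-membered aromatic ring of carbon only, though compound 3 still gives 85 nM as a number in the same assay range. No measurement on hand bears on the reason for this step.

Still open, going by these compounds, is whether the step belongs to the change of ring or to the methyl group, since the two change together here and no acid carries an unsubstituted phenyl at this place. Equally open, on these data alone, are the response to a chlorine atom or a methoxy group in place of that methyl, and how much of the higher number of compound 1 belongs to its ethyl ester rather than to the group at this position.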